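A Chlorophenyl Swap Carried Onto a Stronger Core

The source may hold more compounds than are shown below. What is called first, only, known or untested is meant among the compounds shown, and "the series" means these compounds.

Measured compounds:
compound 1, `COc1ccccc1N1CCN(CN2C(=O)C3CCCN3C2=O)CC1`: 500 nM
compound 2, `O=C1C2CCCN2C(=O)N1CN1CCN(c2cccc(Cl)c2)CC1`: 292 nM
compound 3, `COc1ccccc1N1CCN(CCCN2C(=O)C3CCCCN3C2=O)CC1`: 9.9 nM

In an assay on isolated protein for binding affinity to Adrenergic receptor alpha-1 (Rattus norvegicus), read by radioligand binding (a higher number here means a weaker inhibitor, a lower number a stronger inhibitor), compound 1 gives 500 nM, compound 2 gives 292 nM, and compound 3 gives 9.9 nM; compound 3 stands lowest of the three, beyond the scatter from both others. Compound 4, `O=C1C2CCCCN2C(=O)N1CCCN1CCN(c2cccc(Cl)c2)CC1`, has not yet been measured in this assay.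

The change from compound 1 to compound 2 is 3-chlorophenyl in place of 2-methoxyphenyl on an amine nitrogen in a ring, and it gave a 1.7-fold lower number from compound 1 to compound 2 (0.23 log units; within the scatter). The same change, (3-chlorophenyl in place of 2-methoxyphenyl on an amine nitrogen in a ring), leads from compound 3 to compound 4. How the core of compound 3 differs from the core of compound 1 is not broken down here.

Since the earlier step was small, the step to compound 4 is expected to be a 1.4-fold lower number from compound 3 to compound 4 (0.15 log units; within the scatter), resting on a 1.7-fold lower number from compound 1 to compound 2 (0.23 log units; within the scatter). Compound 4 is therefore estimated at 7 nM, expected between 2.5 nM and 25 nM.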

Compound 4, inhibition constant: 17.9 nM
Compound 4: the middle estimate sits 2.6-fold (0.41 log units) below what was measured; the range from low to high includes it.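

In this assay, putting 3-chlorophenyl in place of 2-methoxyphenyl gave a 1.8-fold higher number from compound 3 to compound 4 (0.26 log units; within the scatter). Each step alone lies within the scatter, yet the two steps point in opposite directions and the gap between them does not, so the change did not carry over as one fixed step from one core to the other: the same change on two cores in this assay, a 1.7-fold lower number (0.23 log units; within the scatter) from compound 1 to compound 2 and a 1.8-fold higher number (0.26 log units; within the scatter) from compound 3 to compound 4, 3.1-fold (0.49 log units) apart, beyond the scatter of two such steps. This does not show which feature of the two cores lies behind the gap, and two pairs set no rule for the series.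

The compounds shown leave open whether an unsubstituted phenyl or a pyridine ring on that amine nitrogen would differ between the cores in the same way. Also open, as far as these compounds go, is what a longer chain alone would do on the core of compound 1.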